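Swapping Methyl for Fluoro: What to Expect of Compound 4

The source may hold more compounds than are shown below. What is called first, only, known or untested is meant among the compounds shown, and "the series" means these compounds.

Measured so far:
Compound 1, `CC(=O)N1N=C(c2ccc(C)cc2)CC1c1cn(-c2ccccc2)nc1-c1ccc(Cl)c(Cl)c1`, gives 27.7% in a functional assay on the whole organism (strain Wistar) for inhibition, with Rattus norvegicus as the target, read by paw edema, with a stated time of 30 min, at a dose of 50 mg/kg by the oral route; a lower number here means less inhibition, a higher number more inhibition at the dose given (going by the name of the read-out).
Compound 2, `CCC(=O)N1N=C(c2ccc(F)cc2)CC1c1cn(-c2ccccc2)nc1-c1ccc(Cl)c(Cl)c1`, gives 51.1% in this assay.
Compound 3, `Cc1ccc(C2=NNC(c3cn(-c4ccccc4)nc3-c3ccc(Cl)c(Cl)c3)C2)cc1`, gives 38.3% in this assay.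

Compound 3 stands second highest of the three numbers in this assay. Going by the values given here, its nearest neighbour is compound 1, and the only step recorded between measured compounds is a number 10.6 percentage points higher from compound 1 to compound 3 (beyond the scatter), a rise beyond the scatter when hydrogen replaces acetyl. Compound 2 lies furthest from compound 3, beyond the scatter on the higher side.

Compound 4, `Fc1ccc(C2=NNC(c3cn(-c4ccccc4)nc3-c3ccc(Cl)c(Cl)c3)C2)cc1`, differs from compound 3 by fluoro in place of methyl on an aromatic carbon. Among the compounds with values here, no recorded step isolates this change. Compound 1 and compound 2 differ both in the group on the amine nitrogen and in methyl against fluoro, so their values only show that compound 2 sits higher than compound 1, without telling which change matters. A small rise is therefore expected in this assay for compound 4, a number 7.7 percentage points higher from compound 3 to compound 4 (within the scatter), and compound 4 is estimated at 46%, between 32% and 62%.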

Compound 4, a percentage reported as inhibition, in the whole organism at one dose (the size of the read-out at that dose, not a potency): 45.7%
Beside the measured number, compound 4's estimate is 0.3 percentage points above it; the range from low to high includes it.
By their numbers in this assay, from the lowest: compound 1; then compounds 3, 4 and 2 (each within the scatter of the next, the first and the last beyond it).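

Going by these compounds alone, compound 3 and compound 4 give the first direct comparison of 4-methylphenyl with 4-fluorophenyl: in this assay the swap gives a number 7.4 percentage points higher from compound 3 to compound 4 (within the scatter) and so cannot be told apart from the scatter at this position on the core with a hydrogen on the ring nitrogen. The second new step, a number 5.4 percentage points lower from compound 2 to compound 4 (within the scatter) with hydrogen in place of propanoyl, also stays within the scatter, whereas hydrogen in place of acetyl gave a number 10.6 percentage points higher from compound 1 to compound 3 (beyond the scatter) with 4-methylphenyl as the aromatic group. Nothing available here explains these numbers.

The compounds shown do not separate the effect of the acyl group from that of the aromatic group, as acetyl appears only with 4-methylphenyl and propanoyl only with 4-fluorophenyl. From the compounds shown here alone, how a chloro, methoxy or trifluoromethyl group would compare at the same position also remains open.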